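The source may hold more compounds than are shown below. What is called first, only, known or untested is meant among the compounds shown, and "the series" means these compounds.

In an assay on cells for displacement of a labelled ligand from prostaglandin E2 receptor EP4 subtype (Homo sapiens), read by scintillation counting (a higher number here means a weaker inhibitor, a lower number a stronger inhibitor), the measured compounds are:
compound 1 `Cc1oc(C(=O)O)cc1COc1ccc(-c2ccc(Cl)cc2)cc1`, 1000 nM;
compound 2 `COc1ccc(-c2ccc(OCc3cc(C(=O)NS(=O)(=O)c4ccccc4)oc3C)cc2)c(C)c1`, 21 nM;
compound 3 `Cc1oc(C(=O)O)cc1COc1ccc(-c2ccc(CO)cc2)cc1`, 3000 nM.

Compound 3 stands with the highest number of the three in this assay. Its nearest neighbour is compound 1, which differs from it in one place only, a chloro where compound 3 carries the hydroxymethyl; the furthest is compound 2, whose number is far lower and whose structure differs from compound 3 in several places at once, so that no single change can be read from it. Among the compounds with values here, the one measured step that turns on this group alone is a 3.0-fold higher number from compound 1 to compound 3 (0.48 log units; beyond the scatter).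

Compound 4 `Cc1oc(C(=O)O)cc1COc1ccc(-c2ccc(C#N)cc2)cc1` has not yet been measured. The change from compound 3 to compound 4 is cyano in place of hydroxymethyl on an aromatic carbon. Within the data shown here, no measured pair shows a cyano entering or leaving, so the only guide is the single step above: the hydroxymethyl that raised the number when it replaced chloro now leaves again, and a partial return toward the number of compound 1 is expected, though the group entering is not the chloro of compound 1. Compound 4 is therefore expected to show a 2.0-fold lower number from compound 3 to compound 4 (0.30 log units; within the scatter) in this assay. The estimate for compound 4 is 1500 nM, with a range from 500 nM to 5000 nM.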

Compound 4, inhibition constant: 1500 nM
Beside the measured number, compound 4's estimate shows no gap at the digits printed; measured number inside the range.
By their numbers in this assay, from the lowest: compound 2; then compounds 1, 4 and 3 (each within the scatter of the next, the first and the last beyond it).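

In this assay, the cyano group on this aromatic carbon, para to a large group, gives a 2.0-fold lower number from compound 3 to compound 4 (0.30 log units; within the scatter) and a 1.5-fold higher number from compound 1 to compound 4 (0.18 log units; within the scatter), so compound 4 cannot be told apart from either neighbour. The position therefore accepts a cyano group, which has no hydrogen-bond donor, and its number stays within the scatter of both the chloro of compound 1 and the hydroxymethyl of compound 3. Since compound 1 and compound 3 are separated by a 3.0-fold higher number from compound 1 to compound 3 (0.48 log units; beyond the scatter) while compound 4 cannot be separated from either, this change does not show whether losing the hydroxymethyl donor matters here, and the three groups span only a narrow band of numbers, far from that of compound 2.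

The compounds shown leave open how an amine, a carboxylic acid or a longer chain such as an alkoxy chain would read on this aromatic carbon, and compound 2 differs in too many places for any share of its number to be assigned to this position. No measurement offered here gives a reason for any of these numbers.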